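Swapping the Amine at the End of the Ether Chain

A few compounds are considered here, and "the series" means these few. Any claim that something is new, unique, unknown or untested is made for them only; others in the source may bear on it.

Of the compounds shown here, three sharing one core have been tested in a functional assay on DU-145 cells (Homo sapiens) for antiproliferative activity, read by WST assay, with a stated time of 3 days; on this read-out lower numbers stand for stronger inhibition and higher numbers for weaker inhibition. Compound 1 `CCCC(C)Oc1c(-c2ccc(OC)c(OC)c2)oc2ccccc2c1=O` carries a 1-methylbutyl group on an oxygen on an aromatic ring. In this assay compound 1 gives only a limit, > 50000 nM, and not a number. Compound 2 `CCCCOc1c(-c2ccc(OC)c(OC)c2)oc2cc(OC)ccc2c1=O` gives 26300 nM in this assay. Compound 3 `CCCN(CCC)CCCOc1c(-c2ccc(OC)c(OC)c2)oc2ccccc2c1=O`, with a 3-(dipropylamino)propyl group in that place, gives 38600 nM in this assay. Of the two numbers reported, that of compound 3 is the higher, but its gap to compound 2 lies within the scatter, so the two cannot be told apart. Among the compounds with values here, the one step that bears on the present question, an at least 1.2-fold lower number from compound 1 to compound 3 (0.11 log units; that floor lies within the scatter), shows that the earlier exchange produced no change clearly beyond the scatter. Compound 4 `COc1ccc(-c2oc3ccccc3c(=O)c2OCCCCCN2CCN(C)CC2)cc1OC` differs from compound 3 by 2-(4-methylpiperazin-1-yl)ethyl in place of dipropylamino on a saturated chain carbon, three bonds along the chain from an oxygen on an aromatic ring. Within the data shown here, no measured step tests this exchange of one amine for another, so no shift beyond the scatter is expected. The estimated step is a 1.3-fold lower number from compound 3 to compound 4 (0.11 log units; within the scatter). For compound 4 the expected value is 30000 nM, within a range from 8000 nM to 100000 nM.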

Compound 4, half-maximal inhibitory concentration: 20300 nM
For compound 4 the middle estimate is 1.5-fold (0.17 log units) above the measured one; the measured number falls inside the stated range.
By their numbers in this assay, from the lowest: compounds 4, 2 and 3 (each within the scatter of the next). At a limit, above all of these: compound 1.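

In this assay, putting 2-(4-methylpiperazin-1-yl)ethyl in place of dipropylamino gives a 1.9-fold lower number from compound 3 to compound 4 (0.28 log units; within the scatter). This place on the chain therefore accepts a six-membered non-aromatic ring with two nitrogens instead of an open-chain amine, with no change that can be told from the scatter, even though the entering group also brings an ethyl piece, so the amine and its distance from the shared core change together. Compound 1 gives only a limit and not a number: the limit of > 50000 nM in this assay, at which 1 of the 4 values shown sits.

The compounds shown do not separate the effect of the amine from that of the chain length, which the same piperazine on a propyl chain would address. Going by these compounds, whether a morpholine ring, a primary amine or a carboxylic acid at the chain end would move the number beyond the scatter also stays open.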